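From fluoro to chloro among compounds held at a limit

The source may report more compounds than this note shows. Statements on the series, on what has been measured and on what is new or still open speak of the compounds shown alone.

In a functional assay on Raji cells (Homo sapiens) for cytotoxicity, with a stated time of 72 h (on this read-out higher numbers stand for an effect only at larger amounts of compound and lower numbers for an effect already at smaller amounts), compound 1 `C=C[C@@](C)(/C=C/c1ccc(OS(=O)(=O)C(F)(F)F)cc1)CCC=C(C)C` gives > 26000 nM as a limit and not a number. Compound 2 `C=C[C@@](C)(/C=C/c1ccc(Nc2ccccc2)cc1)CCC=C(C)C` with its anilino group gives > 26000 nM as a limit too. Compound 3 `C=C[C@@](C)(/C=C/c1ccc(Nc2ccc(Cl)c(F)c2)cc1)CCC=C(C)C` with its (4-chloro-3-fluorophenyl)amino group gives > 26000 nM as a limit as well. Compound 3 therefore has no number of its own, and neither do the two others shown.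

Compound 4 `C=C[C@@](C)(/C=C/c1ccc(Nc2ccc(Cl)c(Cl)c2)cc1)CCC=C(C)C` has not yet been measured. The structural difference is chloro in place of fluoro on an aromatic carbon and it places chloro where fluoro stood, on an aromatic carbon ortho to a chloro group and meta to a large group, so that 4-chloro-3-fluorophenyl becomes 3,4-dichlorophenyl.

The measured steps offer no size to carry over: there is a step that the two limits leave unreadable from compound 1 to compound 2 and a step that the two limits leave unreadable from compound 1 to compound 3 and also a step that the two limits leave unreadable from compound 2 to compound 3 in the series. With compound 3 and both its neighbours at the limit of > 26000 nM in this assay, at which 3 of the 3 values shown sit, there is no measured move on which to base a change in this assay of any size or direction. The expected step is a number no higher from compound 3 to compound 4 (the limit leaves the size open) and nothing beyond the scatter is anticipated. For compound 4 the estimated value is 26000 nM with an expected range from 10000 nM to 50000 nM and most likely only a limit will be reported.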

Compound 4, half-maximal effective concentration: > 26000 nM
Compound 4: a limit, no number; the forecaster's own chance of this, stated with the estimate: 80%; the middle value sits exactly at the limit.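

Among the compounds shown here, compound 4 also gives a limit and not a number in this assay and so no step from compound 1, compound 2 or compound 3 to compound 4 can be read: the limit of > 26000 nM in this assay, at which 4 of the 4 values shown sit.

The compounds shown leave open whether any of them reaches a measurable effect in this assay and whether chloro in place of fluoro changes that effect at all.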